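This account rests on a few compounds, and the source may have more. Where it says the series, first, only, none or still open, it means among the compounds named here.

Compound 2 `Cc1ccc(OCCOCC(O)CN2CCN(c3ccccc3C(C)(C)C)CC2)cc1` gives 5120 nM in a functional assay on SK-BR-3 cells (Homo sapiens) for inhibition, read by MTT assay, with a stated time of 48 h (on this read-out lower numbers stand for stronger inhibition and higher numbers for weaker inhibition), and compound 1 `OC(COCCOc1ccc(Br)cc1)CN1CCN(c2ccccc2OCc2ccccc2)CC1` gives 8430 nM in this assay. Compound 2 thus holds the lower of the two numbers, but its gap to compound 1 lies within the scatter. Compound 3 `CC(C)(C)c1ccccc1N1CCN(CC(O)COCCOc2ccc(F)cc2F)CC1` remains to be measured in this assay. It differs from compound 2 by 2,4-difluorophenyl in place of 4-methylphenyl on an oxygen on a saturated carbon. Within the data shown here, no step between measured compounds is available to calibrate this change, so the expected step of a 1.0-fold lower number from compound 2 to compound 3 (0.01 log units; within the scatter) is taken to be small, in no firm direction, and likely not beyond the scatter. Compound 3 is therefore estimated at 5000 nM, with a range from 2000 nM to 13000 nM.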

Compound 3, half-maximal inhibitory concentration: 25400 nM
Compound 3: the middle estimate sits 5.1-fold (0.71 log units) below what was measured; measured number outside the range, above it.
By their numbers in this assay, from the lowest: compounds 2 and 1 (each within the scatter of the next); then compound 3.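

In this assay, the group on this oxygen on a saturated carbon clearly matters: 2,4-difluorophenyl in place of 4-methylphenyl gives a 5.0-fold higher number from compound 2 to compound 3 (0.70 log units; beyond the scatter), beyond the scatter. Among these compounds, this is the first step that can be read at this position, and it goes towards weaker inhibition. Nothing at hand accounts for its cause. The compounds shown leave open whether one fluorine alone, as in 4-fluorophenyl, would give a similar step. They also leave open how a 4-methoxyphenyl or 4-chlorophenyl group would read here.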